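Notes on compound 4: hydrogen in place of fluoro

This account rests on a few compounds, and the source may have more. Where it says the series, first, only, none or still open, it means among the compounds named here.

Measured so far:
compound 1 `Cc1nc2c(c(-c3cc(F)c4c(c3C)CCCO4)c1[C@H](OC(C)(C)C)C(=O)O)CN(CCCc1cccc(F)c1)CC2` — in an ADME assay on MT2 cells (Homo sapiens) for cytotoxicity, read by XTT assay, with a stated time of 4 days (on this read-out higher numbers stand for lower toxicity in this test and lower numbers for higher toxicity in this test), compound 1 gives only a limit, > 40000 nM.
compound 2 `Cc1ccc(-c2c3c(nc(C)c2[C@H](OC(C)(C)C)C(=O)O)CCN(C(=O)OCc2ccccc2)C3)cc1` — in this assay compound 2 gives only a limit, > 40000 nM.
compound 3 `Cc1ccc(-c2c3c(nc(C)c2[C@H](OC(C)(C)C)C(=O)O)CCN(c2ccccc2)C3)cc1` — in this assay compound 3 gives only a limit, > 40000 nM.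

Compound 1 stands nowhere in particular on these numbers: its value is a limit, not a number, and the same holds for the two other values, all of which sit at the limit of > 40000 nM in this assay, at which 3 of the 3 values shown sit. Going by the values given here, the one step between compounds differing in a single place, a step that the two limits leave unreadable from compound 2 to compound 3, is therefore unreadable in size and direction.

The unmeasured compound 4 `Cc1nc2c(c(-c3cc(F)c4c(c3C)CCCO4)c1[C@H](OC(C)(C)C)C(=O)O)CN(CCCc1ccccc1)CC2` differs from compound 1 by hydrogen in place of fluoro on an aromatic carbon. Among the compounds with values here, no measured step bears on this change: compounds 2 and 3 differ from each other on the ring amine nitrogen, not on a six-membered aromatic ring of carbon only, and their values say nothing beyond the shared limit.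

Given that every value shown rests at the limit of > 40000 nM in this assay, at which 3 of the 3 values shown sit, compound 4 is expected to show no step beyond the scatter, so the estimated step is a step that the limit leaves unreadable from compound 1 to compound 4. For compound 4 the estimate in this assay is 60000 nM, within a range of 25000 nM to 150000 nM, most likely again reported only as a limit.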

Compound 4, half-maximal cytotoxic concentration: > 40000 nM
Compound 4 ended at the assay's limit; the forecaster's own chance of this, stated with the estimate: 85%; the middle value is on the limit's open side.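

Compound 1 and compound 4 both rest at a limit rather than a number in this assay, so no step can be read for hydrogen in place of fluoro: the limit of > 40000 nM in this assay, at which 4 of the 4 values shown sit.

The compounds shown leave open whether any change on the shared core moves the read-out in this assay, and at what concentration any of them would turn cytotoxic.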